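This account rests on a few compounds, and the source may have more. Where it says the series, first, only, none or still open, it means among the compounds named here.

Measured so far in an ADME assay on the whole organism for inhibition, with Echinochloa crus-galli var. formosensis as the target, with a stated time of 4 days; a lower number here means a stronger inhibitor, a higher number a weaker inhibitor:
- compound 1 `CC[C@H](C)Nc1nc(Cl)nc(N[C@@H](C)c2ccccc2)n1`: 14100 nM
- compound 2 `CCCCNc1nc(Cl)nc(N[C@@H](C)c2ccccc2)n1`: 12900 nM
- compound 3 `CCCN(C)c1nc(Cl)nc(N[C@@H](C)c2ccccc2)n1`: 380 nM

Compound 3 gives the lowest number of the three. Compound 4 `CCN(CC)c1nc(Cl)nc(N[C@@H](C)c2ccccc2)n1` is next, with diethylamino in place of methyl(propyl)amino on an aromatic carbon. For the measured compounds named here, the two groups have the same atoms, joined differently, and the closest precedent is a 1.1-fold lower number from compound 1 to compound 2 (0.04 log units; within the scatter), another rearrangement at this place. The large steps of a 37-fold lower number from compound 1 to compound 3 (1.57 log units; beyond the scatter) and a 34-fold lower number from compound 2 to compound 3 (1.53 log units; beyond the scatter) show that this place can matter, although neither compares two groups of this kind, so the range stays wide. In this assay, the estimated step is a 1.3-fold higher number from compound 3 to compound 4 (0.12 log units; within the scatter), with nothing expected beyond the scatter. The expected value for compound 4 is 500 nM, with an estimated range of 150 nM to 2000 nM.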

Compound 4, half-maximal inhibitory concentration: 257 nM
Estimate against measurement, compound 4: 1.9-fold (0.29 log units) above; low and high end bracket the measured number.
By their numbers in this assay, from the lowest: compounds 4 and 3 (each within the scatter of the next); then compounds 2 and 1 (each within the scatter of the next).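

In this assay, the rearrangement of methyl(propyl)amino to diethylamino gives a 1.5-fold lower number from compound 3 to compound 4 (0.17 log units; within the scatter) so the low number at this position does not depend on methyl(propyl)amino alone. Diethylamino also gives a 50-fold lower number from compound 2 to compound 4 (1.70 log units; beyond the scatter) and a 55-fold lower number from compound 1 to compound 4 (1.74 log units; beyond the scatter) so both groups with two carbon chains on this nitrogen stand apart from butylamino and (sec-butyl)amino, and no compound shown goes against this. Nothing available accounts for that gap.

From the compounds shown here alone, whether the gap persists with smaller or longer chains, such as dimethylamino or dipropylamino, remains open.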